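Isopropoxy in place of methoxy on the core of compound 2

The source may report more compounds than this note shows. Statements on the series, on what has been measured and on what is new or still open speak of the compounds shown alone.

Measured compounds:
compound 1, `Cc1cccc(NC(=O)c2nc(C)ccc2O)n1`, 7 nM
compound 2, `COc1cccnc1Nc1cccc(C)n1`, 458 nM

Of the compounds shown here, two have been measured in an assay on Ltk cells with metabotropic glutamate receptor 5 (Homo sapiens) as the target, read by fluorescence and calcium flux; a lower number here means a stronger inhibitor, a higher number a weaker inhibitor. Compound 1 gives 7 nM. Compound 2 gives 458 nM, the higher of the two numbers; the gap to compound 1 lies well beyond the usual scatter of repeated measurements, so compound 2 stands as the weaker inhibitor of the pair on what has been seen so far.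

Compound 3, `Cc1cccc(Nc2ncccc2OC(C)C)n1`, has not yet been measured. It differs from compound 2 in one place: isopropyl in place of methyl on an oxygen on an aromatic ring. The methoxy group of compound 2 thus becomes an isopropoxy group, and the rest of the structure stays as it is.

Among the measured compounds shown here, no measured pair shows what this change does in this assay. With nothing to lean on, the step from compound 2 to compound 3 is expected to be small, most likely within the scatter, with no firm direction. On that basis compound 3 is estimated to give 350 nM, with a range from 90 nM to 1500 nM, which means an expected step of a 1.3-fold lower number from compound 2 to compound 3 (0.12 log units; within the scatter).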

Compound 3, half-maximal inhibitory concentration: 1000 nM
For compound 3 the middle estimate is 2.9-fold (0.46 log units) below the measured one, within the range that was stated.
By their numbers in this assay, from the lowest: compound 1; then compound 2; then compound 3.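

In this assay, isopropyl in place of methyl on an oxygen on an aromatic ring gives a 2.2-fold higher number from compound 2 to compound 3 (0.34 log units; beyond the scatter). Among the compounds shown here, the step is modest but beyond the usual scatter, so this is the first sign that the group on this oxygen affects inhibition and that, of the two groups seen here, methoxy gives the stronger inhibitor. The added carbons bring no gain on this core, although one step cannot show how the number would move across a wider set of groups, and nothing at hand bears on why it rose.

The compounds shown leave open whether an ethoxy group would fall between methoxy and isopropoxy, or whether the number keeps rising with a longer chain such as butoxy or with a cyclopropylmethoxy group. They also leave open whether a free hydroxyl group, or an amine in place of the ether oxygen, would give a lower number than methoxy, and whether the same change would have a similar effect on another core.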